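Replacing methylsulfanyl with piperidin-1-yl on compound 1

The source may hold more compounds than are shown below. What is called first, only, known or untested is meant among the compounds shown, and "the series" means these compounds.

For the measured compounds named here, compound 1, `CSc1c(C)c(-c2ccccc2)c(C#N)c(N)c1C#N`, is one of two compounds measured in an assay on isolated protein for inhibition of glucose-6-phosphatase catalytic subunit 1 (Homo sapiens), tested at 100 uM; a lower number here means less inhibition, a higher number more inhibition at the concentration tested (going by the name of the read-out). In this assay compound 1 gives 0.96%, the lower of the two numbers. Going by the values given here, its only measured neighbour is compound 2, `COc1ccc(-c2c(C)c(SC)c(C#N)c(N)c2C#N)cc1`, which carries a methoxy in place of a hydrogen on an aromatic carbon and gives 12.3%, a step of a number 11.3 percentage points higher from compound 1 to compound 2 (beyond the scatter). Compound 3, `Cc1c(-c2ccccc2)c(C#N)c(N)c(C#N)c1N1CCCCC1`, has not yet been measured. It differs from compound 1 at another place: piperidin-1-yl in place of methylsulfanyl on an aromatic carbon. Among the compounds with values here, no measured step touches the methylsulfanyl group, so the single known step bears on compound 3 only indirectly, showing that one change to the shared core can move inhibition by a modest amount. Because compound 1 sits at 0.96%, close to no inhibition, there is little room for a downward move. The step of a number 5 percentage points higher from compound 1 to compound 3 (within the scatter) is therefore expected to be small, leaning upward if anywhere. Compound 3 is estimated at 6%, with a range from 0% to 20%.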

Compound 3, a percentage reported as inhibition, at one concentration (the size of the read-out at that concentration, not a potency): 38.2%
Compound 3: the middle estimate sits 32.2 percentage points below what was measured, outside the stated range (above it).
By their numbers in this assay, from the lowest: compound 1; then compound 2; then compound 3.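

The position that carries methylsulfanyl, on an aromatic carbon ortho to a cyano group and to a methyl group, proves highly responsive in this assay: piperidin-1-yl there gives a number 37.2 percentage points higher from compound 1 to compound 3 (beyond the scatter), a large step, whereas the methoxy on the phenyl ring gave the modest a number 11.3 percentage points higher from compound 1 to compound 2 (beyond the scatter). So the near-absent inhibition of compound 1 is not fixed by the shared core, and among these compounds a single change at this position moves the read-out more than the one change seen elsewhere, although each figure is a reading at one concentration and not a potency. No measurement here explains why this exchange of a group without a ring for a six-membered non-aromatic ring holding nitrogen raises inhibition.

The compounds shown cannot separate the contribution of the ring from that of the nitrogen, so an open-chain dimethylamino group or a smaller pyrrolidin-1-yl ring at this position would be informative. Also open, from the compounds shown here alone, is whether the methoxy of compound 2 and the piperidin-1-yl of compound 3 would add up on one molecule.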